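This account rests on a few compounds, and the source may have more. Where it says the series, first, only, none or still open, it means among the compounds named here.

Measured so far in a functional assay on MCF7 cells (Homo sapiens) for cytotoxicity, read by MTT assay, with a stated time of 48 h (a lower number here means a stronger inhibitor, a higher number a weaker inhibitor), all three values being limits:
- compound 1 `COc1cc(-n2c(-c3ccc(O)cc3)c[nH]c2=O)cc(OC)c1OC`: > 50000 nM
- compound 2 `COc1ccc(-c2c[nH]c(=O)n2-c2cc(OC)c(OC)c(OC)c2)cc1N`: > 50000 nM
- compound 3 `COc1cc(NC(=O)n2cc(-c3ccc(O)cc3)n(-c3cc(OC)c(OC)c(OC)c3)c2=O)cc(OC)c1OC`: > 50000 nM

Compound 3 stands at > 50000 nM, which is a limit and not a number. For the measured compounds named here, the same holds across the series so far: the limit of > 50000 nM in this assay, at which 3 of the 3 values shown sit. Going by the values given here, no compound can therefore be ranked against another on these data.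

Compound 4 `COc1ccc(-c2cn(C(=O)Nc3cc(OC)c(OC)c(OC)c3)c(=O)n2-c2cc(OC)c(OC)c(OC)c2)cc1N` is compound 3 with one exchange, 3-amino-4-methoxyphenyl in place of 4-hydroxyphenyl on an aromatic carbon.

Among the compounds with values here, one measured step bears on this and carries the same exchange: a step that the two limits leave unreadable from compound 1 to compound 2. That step was made without the substituent that compounds 3 and 4 share. Both ends of that step are limits, so it gives no size and no direction. Compound 2, the product of that exchange, remains a limit at > 50000 nM. Within the data shown here, nothing measured so far therefore points to a gain in this assay from this exchange, and another limit is the likeliest reading for compound 4.

The expected change, a number no higher from compound 3 to compound 4 (the limit leaves the size open), is none beyond the scatter. For compound 4 the estimated value is 50000 nM, with an expected range of 20000 nM to 100000 nM.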

Compound 4, half-maximal inhibitory concentration: > 50000 nM
Compound 4 gave a limit, no number (the forecaster's own chance of this, stated with the estimate: 80%); the middle value lies on the limit itself.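

Compound 4 in this assay gives > 50000 nM, which is a limit and not a number. Compound 3 is also a limit, so no step can be read between compound 3 and compound 4, and the series shows one reading: the limit of > 50000 nM in this assay, at which 4 of the 4 values shown sit.

Which change, if any, would bring a compound of this series to a measurable value in this assay stays open.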